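The source may report more compounds than this note shows. Statements on the series, on what has been measured and on what is new or still open speak of the compounds shown alone.

Measured compounds in a functional assay on WiDr cells (Homo sapiens) for inhibition, read by sulforhodamine B assay, with a stated time of 48 h; a lower number here means a stronger inhibitor of growth, a higher number a weaker inhibitor of growth:
- compound 1 `COC(=O)[C@@]1(C)CCC=C2[C@@H]1CC[C@@H](C)[C@]2(C)Cc1c(C)[nH]c2ccccc12`: 19000 nM
- compound 2 `COC(=O)[C@@]1(C)CCC=C2[C@@H]1CC[C@@H](C)[C@]2(C)Cc1c(C)[nH]c2c(Cl)cccc12`: 29000 nM
- compound 3 `COC(=O)[C@@]1(C)CC[C@@H]2C3=C1CC[C@@H](C)[C@]3(C)Cc1c2[nH]c2ccccc12`: 4000 nM

Compound 3 gives the lowest number of the three in this assay; the values of compound 1 and compound 2 both lie above it by more than the scatter. Compound 4 `COC(=O)[C@@]1(C)CC[C@@H]2C3=C1CC[C@@H](C)[C@]3(C)Cc1c2[nH]c2ccc(OC)cc12` differs from compound 3 by methoxy in place of hydrogen on an aromatic carbon. Going by the values given here, the only measured step that bears on a substituent entering an aromatic carbon of the shared core is a 1.5-fold higher number from compound 1 to compound 2 (0.18 log units; within the scatter), which is within the scatter. Among the compounds with values here, no measured step covers methoxy. On that basis, no step beyond the scatter is expected in this assay from compound 3 to compound 4, in either direction. Compound 4 is therefore estimated at 4000 nM, with a range of 1500 nM to 11000 nM, which corresponds to an expected step of no change at the digits printed from compound 3 to compound 4 (within the scatter).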

Compound 4, concentration for 50% growth inhibition: 1200 nM
Compound 4: middle estimate off by 3.3-fold (0.52 log units), on the high side, outside the stated range (below it).
By their numbers in this assay, from the lowest: compound 4; then compound 3; then compounds 1 and 2 (each within the scatter of the next).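

In this assay, methoxy in place of hydrogen on an aromatic carbon gives a 3.3-fold lower number from compound 3 to compound 4 (0.52 log units; beyond the scatter), so this place on the core of compound 3 responds to substitution by more than the scatter. The earlier step, a 1.5-fold higher number from compound 1 to compound 2 (0.18 log units; within the scatter), involved chloro on a different core and did not show this. No measurement shown gives a reason for the step.

As far as these compounds go, whether hydroxy, an amine or a longer alkoxy chain at this carbon would give a similar step remains open. So does whether methoxy would give the same step on the core of compound 1.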